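A few compounds are considered here, and "the series" means these few. Any claim that something is new, unique, unknown or untested is made for them only; others in the source may bear on it.

Compound 1 `CCOC(=O)C12C(=O)OCC=C1COC2c1ccc(F)cc1` is known in a functional assay on QGY cells (Homo sapiens) for cytotoxicity, read by MTT assay (on this read-out lower numbers stand for stronger inhibition and higher numbers for weaker inhibition), only as a limit, since compound 1 gives > 1000000 nM. Compound 2 `CCOC(=O)C12C(=O)OCC=C1COC2c1cccc(Cl)c1` likewise gives only the limit > 1000000 nM. The step that the two limits leave unreadable from compound 1 to compound 2 therefore cannot be read, both values sitting at the limit of > 1000000 nM in this assay, at which 2 of the 2 values shown sit. Compound 3 `CCOC(=O)C12C(=O)OCC=C1COC2c1ccc(C(C)(C)C)cc1` differs from compound 1 by tert-butyl in place of fluoro on an aromatic carbon. Going by the values given here, no measured step bears on this change; all that is known is that neither compound 1 nor compound 2 reached a number. Compound 3 is accordingly expected to stay near the same limit, the estimated step being a number no higher from compound 1 to compound 3 (the limit leaves the size open). The estimate for compound 3 is 1000000 nM, ranging from 200000 nM to 5000000 nM.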

Compound 3, half-maximal inhibitory concentration: > 1000000 nM
Compound 3: only a limit was reported; the forecaster's own chance of this, stated with the estimate: 85%; the middle value lies on the limit itself.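

Going by these compounds alone, compound 3 also gives only a limit (> 1000000 nM), so no step from compound 1 to compound 3 can be read: the limit of > 1000000 nM in this assay, at which 3 of the 3 values shown sit. Going by these compounds, whether any group on this aromatic carbon gives a readable number in this assay stays open.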